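Ester to piperidine amide on the glycine-urea side chain

A few compounds are considered here, and "the series" means these few. Any claim that something is new, unique, unknown or untested is made for them only; others in the source may bear on it.

Of the compounds shown here, three sharing one core have been measured in a functional assay on HEK293 cells for agonist activity at Vasopressin V2 receptor (Homo sapiens), read by a luciferase reporter and cAMP accumulation; a lower number here means that less compound is needed, a higher number that more compound is needed for the effect. Compound 1 `O=C(NCc1ccc(C(=O)N2CCCCc3ccccc32)c(Cl)c1)Nc1c(F)cccc1F` gives 40 nM. Compound 2 `CCc1cc(C(=O)N2CCCCc3ccccc32)ccc1CNC(=O)Nc1c(F)cccc1F` gives 10 nM. Compound 3 `CCOC(=O)CNC(=O)NCc1ccc(C(=O)N2CCCCc3ccccc32)cc1C`, whose urea carries an ester-bearing chain rather than the difluorophenyl group of the other two, gives 140 nM, the highest number of the three; its nearest neighbour is compound 1, and the gap to compound 2 is wider still, both beyond the scatter.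

Compound 4 `Cc1cc(C(=O)N2CCCCc3ccccc32)ccc1CNC(=O)NCC(=O)N1CCCCC1` has not yet been measured. It differs from compound 3 in one place: piperidin-1-yl in place of ethoxy on a carbonyl carbon, so that the ethoxycarbonyl becomes a (piperidin-1-yl)carbonyl and the ((ethoxycarbonyl)methyl)amino becomes a (((piperidin-1-yl)carbonyl)methyl)amino. Among the measured compounds shown here, no step between two measured compounds reproduces this change, and compounds 1 and 2 differ from compound 3 in several places at once, so they give no direct guide to its size.

With the urea and the rest of the core untouched, the expectation for compound 4 is a modest movement toward a lower number, a 1.4-fold lower number from compound 3 to compound 4 (0.15 log units; within the scatter), a step that may well stay within the scatter. Compound 4 is therefore estimated at 100 nM, with a likely range from 30 nM to 400 nM.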

Compound 4, half-maximal effective concentration: 150 nM
The estimate for compound 4 lay 1.5-fold (0.18 log units) below the measured number, within the range that was stated.
By their numbers in this assay, from the lowest: compound 2; then compound 1; then compounds 3 and 4 (each within the scatter of the next).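

In this assay, among the compounds shown here, the change from ethoxy to piperidin-1-yl on a carbonyl carbon gives the first step in this set that alters a single place, and it reads a 1.1-fold higher number from compound 3 to compound 4 (0.03 log units; within the scatter). Turning the ester into an amide, with 3 heavy atoms leaving and 6 entering along with a six-membered non-aromatic ring, therefore leaves the read-out indistinguishable, so this place on the glycine-urea side chain accepts a much larger ring-bearing group without a measurable difference for this one pair. No measurement on hand bears on why the two compounds cannot be told apart in this read-out.

The compounds shown leave open whether this holds for other groups on the same carbonyl carbon, such as a free carboxylic acid, a small open-chain amine such as dimethylamino, or a morpholine ring, and whether a longer chain in place of the methyl link would behave alike. They also leave open how this side chain relates to the difluorophenyl urea of compound 1 and compound 2, since those compounds differ from compound 3 and compound 4 in more than one place.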